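A few compounds are considered here, and "the series" means these few. Any claim that something is new, unique, unknown or untested is made for them only; others in the source may bear on it.

Measured compounds and their values:

Compound 1, `O=C1/C(=C/c2ccncc2)CN(S(=O)(=O)c2ccc([N+](=O)[O-])cc2)C/C1=C\c1ccccc1F`: 8800 nM
Compound 2, `O=C1/C(=C/c2ccncc2)CN(S(=O)(=O)c2ccc(C(F)(F)F)cc2)C/C1=C\c1ccccc1F`: 9500 nM
Compound 3, `O=C1/C(=C/c2cccnc2)CN(S(=O)(=O)c2ccc([N+](=O)[O-])cc2)C/C1=C\c1ccccc1C(F)(F)F`: 7660 nM

All three were tested in a functional assay on QGY-7703 cells (Homo sapiens) for cytotoxicity, read by MTT assay, with a stated time of 24 h; on this read-out higher numbers stand for weaker inhibition and lower numbers for stronger inhibition. Compound 1 and compound 2 share one core and differ only in one group: trifluoromethyl in place of nitro on an aromatic carbon. That change made a 1.1-fold higher number from compound 1 to compound 2 (0.03 log units; within the scatter), so the two compounds are not told apart by this measurement. Compound 3 carries a different core; how its core differs from that of compound 1 is not broken down here. Its value and that of compound 1 lie within the scatter of each other, as do its value and that of compound 2.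

Compound 4, `O=C1/C(=C/c2cccnc2)CN(S(=O)(=O)c2ccc(C(F)(F)F)cc2)C/C1=C\c1ccccc1C(F)(F)F`, has not yet been measured in this assay. It differs from compound 3 by trifluoromethyl in place of nitro on an aromatic carbon, the same change that led from compound 1 to compound 2. Because that earlier change gave a 1.1-fold higher number from compound 1 to compound 2 (0.03 log units; within the scatter), the step from compound 3 to compound 4 is expected to be of similar size, a 1.1-fold higher number from compound 3 to compound 4 (0.03 log units; within the scatter), that is, within the scatter. For compound 4 the estimated value in this assay is 8200 nM, with a likely range from 4500 nM to 15000 nM.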

Compound 4, half-maximal inhibitory concentration: 1500 nM
Estimate against measurement, compound 4: 5.5-fold (0.74 log units) above, and the stated range ends above it.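

In this assay, putting trifluoromethyl in place of nitro gave a 5.1-fold lower number from compound 3 to compound 4 (0.71 log units; beyond the scatter), so on this core the swap gives stronger inhibition, even though it gave no measurable change on the other core. The effect of this change therefore did not carry over from one core to the other, and a step measured on one core was a poor guide to the step on the other: the same change on two cores in this assay, a 1.1-fold higher number (0.03 log units; within the scatter) from compound 1 to compound 2 and a 5.1-fold lower number (0.71 log units; beyond the scatter) from compound 3 to compound 4, 5.5-fold (0.74 log units) apart, beyond the scatter of two such steps. This shows only that the size of the step can depend on the core; with a single pair on each core, it does not show which feature of the cores is responsible, nor does it give a rule for other cores in the series.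

The compounds shown leave open what a core sharing only part of the features of compound 3 would do with the same swap. They also leave open how other groups on that aromatic carbon, such as an amine or a carboxylic acid, would compare with nitro and trifluoromethyl on each core.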